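Series notes: pyrrolidine ether in place of pyrazole

The source may report more compounds than this note shows. Statements on the series, on what has been measured and on what is new or still open speak of the compounds shown alone.

Compound 2 `Cc1c(Cc2ccc(-c3ccn(C)n3)cc2)cc(C(=O)N[C@H]2CCCC[C@@H]2O)c(=O)n1C` gives 13 10^-6 cm/s in an ADME assay on MDCKII-LE cells (Canis lupus familiaris) for permeability; a lower number here means that the compound crosses the layer more slowly, a higher number that the compound crosses the layer faster. Of the two numbers shown it is the lower, but its only neighbour, compound 1 `Cc1c(Cc2ccc(-c3cocn3)cc2)cc(C(=O)N[C@H]2CCCC[C@@H]2O)c(=O)n1C`, gives 26 10^-6 cm/s, and the step of a 2.0-fold lower number from compound 1 to compound 2 (0.30 log units; within the scatter) lies within the scatter, so the two are not distinguished. Compound 3 `CO[C@@H]1CCN(c2ccc(Cc3cc(C(=O)N[C@H]4CCCC[C@@H]4O)c(=O)n(C)c3C)cc2)C1` differs from compound 2 by 3-methoxypyrrolidin-1-yl in place of 1-methyl-1H-pyrazol-3-yl on an aromatic carbon. Among the measured compounds shown here, only one measured step exists, and it exchanges one five-membered aromatic ring for another on the same carbon; the change to compound 3 brings in a non-aromatic ring in that position, so that step is at best a loose guide. With a single within-scatter step as the sole reference, nothing beyond the scatter is expected in either direction. Compound 3 is therefore estimated at 12 10^-6 cm/s in this assay, with a range of 5 10^-6 cm/s to 28 10^-6 cm/s, which means an expected step of a 1.1-fold lower number from compound 2 to compound 3 (0.03 log units; within the scatter).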

Compound 3, apparent permeability: 23 10^-6 cm/s
Beside the measured number, compound 3's estimate is 1.9-fold (0.28 log units) below it; low and high end bracket the measured number.
By their numbers in this assay, from the lowest: compounds 2, 3 and 1 (each within the scatter of the next).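

Among the compounds shown here, at this place, on an aromatic carbon para to a large group, the earlier compounds held only five-membered aromatic rings, and compound 3 now extends the comparison in this assay to a five-membered non-aromatic ring with a defined stereocentre. Replacing either aromatic ring with 3-methoxypyrrolidin-1-yl gives no step beyond the scatter (a 1.8-fold higher number from compound 2 to compound 3 (0.25 log units; within the scatter); a 1.1-fold lower number from compound 1 to compound 3 (0.05 log units; within the scatter)), so loss of aromaticity at this place does not separate compound 3 from compound 1 or compound 2 in this assay. No available evidence explains these numbers.

Still open, going by these compounds, is whether the methoxy group or its stereochemistry matters, which the opposite stereoisomer and unsubstituted pyrrolidin-1-yl would test. Also open, on these data alone, is whether a carboxylic acid or an open-chain amine at this carbon would give a step beyond the scatter.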